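Chain extension on two cores: expectation for compound 4

The compounds below may be only part of what the source reports. "The series", "measured", "known", "first", "only" and "open" are said of these compounds alone.

All three measured compounds were read in a functional assay on HepG2 cells (Homo sapiens) for antiproliferative activity, read by MTT assay, with a stated time of 48 h; on this read-out higher numbers stand for weaker inhibition and lower numbers for stronger inhibition:
compound 1 `COc1cc2oc(-c3ccccc3)cc(=O)c2c(O)c1OCCCCN1CCN(C)CC1` gives 36700 nM
compound 2 `CN1CCN(CCCOc2c(OCc3ccccc3)cc3oc(-c4ccccc4)cc(=O)c3c2O)CC1` gives 2400 nM
compound 3 `COc1cc2oc(-c3ccccc3)cc(=O)c2c(O)c1OCCCN1CCN(C)CC1` gives 15100 nM

Compound 3 and compound 1 share a core and differ by (4-methylpiperazin-1-yl)methyl in place of 4-methylpiperazin-1-yl on a saturated chain carbon, three bonds along the chain from an oxygen on an aromatic ring. That step reads a 2.4-fold higher number from compound 3 to compound 1 (0.39 log units; beyond the scatter). The core of compound 2 differs from the core of compound 3 by phenyl in place of hydrogen on a saturated chain carbon bound to an oxygen on an aromatic ring, and that step reads a 6.3-fold higher number from compound 2 to compound 3 (0.80 log units; beyond the scatter). Compound 2 holds the lowest number of the three in this assay, and both of its steps to the others lie beyond the scatter.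

Compound 4 `CN1CCN(CCCCOc2c(OCc3ccccc3)cc3oc(-c4ccccc4)cc(=O)c3c2O)CC1` is not yet measured. It differs from compound 2 by (4-methylpiperazin-1-yl)methyl in place of 4-methylpiperazin-1-yl on a saturated chain carbon, three bonds along the chain from an oxygen on an aromatic ring. The place is the same, word for word, as in the pair from compound 3 to compound 1, so this is the same change made on the other core. Going by the values given here, only that one earlier instance exists, so the expectation rests on it alone. Compound 4 is expected to give 5800 nM in this assay, within a range from 2500 nM to 13000 nM. Among the compounds with values here, as a step this expectation is a 2.4-fold higher number from compound 2 to compound 4 (0.38 log units; beyond the scatter), set beside the earlier step because a 2.4-fold higher number from compound 3 to compound 1 (0.39 log units; beyond the scatter) is the only measure of this change.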

Compound 4, half-maximal inhibitory concentration: 2500 nM
For compound 4 the middle estimate is 2.3-fold (0.37 log units) above the measured one; low and high end bracket the measured number.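

In this assay the change from 4-methylpiperazin-1-yl to (4-methylpiperazin-1-yl)methyl reads a 1.0-fold higher number from compound 2 to compound 4 (0.02 log units; within the scatter), and the two readings of this change on the two cores do not differ beyond what two such steps allow: the same change on two cores in this assay, a 2.4-fold higher number (0.39 log units; beyond the scatter) from compound 3 to compound 1 and a 1.0-fold higher number (0.02 log units; within the scatter) from compound 2 to compound 4, 2.3-fold (0.37 log units) apart, within the scatter of two such steps

Phenyl in place of hydrogen, read on the longer chain, gives a 15-fold lower number from compound 1 to compound 4 (1.17 log units; beyond the scatter), and this change also reads alike in the two settings: the same change on two cores in this assay, a 6.3-fold higher number (0.80 log units; beyond the scatter) from compound 2 to compound 3 and a 15-fold higher number (1.17 log units; beyond the scatter) from compound 4 to compound 1, 2.3-fold (0.37 log units) apart, within the scatter of two such steps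

Going by these compounds alone, each change has only two readings, so these notes show agreement within the scatter for this small set, but they do not show that either change keeps a fixed size on a further core, nor whether the chain change has any real effect on the core of compound 2.

Still open, from the compounds shown here alone, is how a shorter chain, such as 2-(4-methylpiperazin-1-yl)ethyl, reads on either core, and whether morpholine or piperidine in place of the methylpiperazine follows the same steps. Also open, going by these compounds, is whether cyclohexyl in place of the phenyl on that chain carbon carries across both cores in the same way.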